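A few compounds are considered here, and "the series" means these few. Any claim that something is new, unique, unknown or untested is made for them only; others in the source may bear on it.

Measured compounds:
compound 1, `Nc1nc(N)nc(-c2cc(Br)ccc2Br)n1`: 2.09
compound 2, `Nc1nc(N)nc(-c2c(Cl)cccc2Cl)n1`: 1.38

Of the compounds shown here, two sharing the same core have been measured in a physicochemical assay for lipophilicity; on this read-out higher numbers stand for higher lipophilicity and lower numbers for lower lipophilicity. Compound 1 gives 2.09 and stands highest of the two numbers; the nearest is compound 2, which gives 1.38, a number lower by an amount beyond the scatter. Going by the values given here, no pair of measured compounds differs in only one place, so these two values can only be set side by side: the compound carrying chloro groups rather than bromo groups shows the lower number.

Compound 3, `Nc1nc(N)nc(-c2cc(Cl)ccc2Br)n1`, has not yet been measured. Against compound 1 its change is chloro in place of bromo on an aromatic carbon. With only the side-by-side reading of compound 1 and compound 2 to go on, a small downward step a number 0.24 log units lower from compound 1 to compound 3 (within the scatter) is expected, close to the usual scatter rather than clearly beyond it. In this assay compound 3 is therefore expected to give about 1.85, with a range from 1.5 to 2.2.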

Compound 3, partition coefficient: 1.85
Compound 3: middle estimate and measured number agree at the digits printed, within the range that was stated.
By their numbers in this assay, from the lowest: compound 2; then compounds 3 and 1 (each within the scatter of the next).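

Going by these compounds alone, compound 1 and compound 3 are the first measured pair that differ in one place, so in this assay the swap of bromo for chloro can now be read on its own (a number 0.24 log units lower from compound 1 to compound 3 (within the scatter)) without any other change in the structure. On this aromatic carbon, meta to a group of 8 heavy atoms and para to a bromo group, the two halogens therefore cannot be told apart on this read-out. Nothing available explains the size of this step.

Still open, as far as these compounds go, is what a group of another kind, such as an amine, a carboxylic acid or a longer chain, would do at this same position. From the compounds shown here alone, it is also open whether replacing the other bromo group, which compound 1 and compound 3 share, would give a similarly small step.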